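A Thiophene Ring at the End of the Chain

The compounds below may be only part of what the source reports. "The series", "measured", "known", "first", "only" and "open" are said of these compounds alone.

Compound 1 `C=C/C=C\[C@H](C)[C@H](OC(N)=O)[C@@H](C)[C@H](O)[C@@H](C)C/C(C)=C\[C@H](C)[C@@H](O)[C@@H](C)/C=C\CCc1ccc(C)c(F)c1` gives the highest number of the three measured compounds in a functional assay on SK-OV-3 cells (Homo sapiens) for cytotoxicity (a higher number here means a weaker inhibitor, a lower number a stronger inhibitor), with compound 1 at 1000 nM. Compound 2 `C=C/C=C\[C@H](C)[C@H](OC(N)=O)[C@@H](C)[C@H](O)[C@@H](C)C/C(C)=C\[C@H](C)[C@@H](O)[C@@H](C)/C=C\CCc1cccc(F)c1` gives 400 nM in this assay, and compound 3 `C=C/C=C\[C@H](C)[C@H](OC(N)=O)[C@@H](C)[C@H](O)[C@@H](C)C/C(C)=C\[C@H](C)[C@@H](O)[C@@H](C)/C=C\CCc1ccccc1` gives 350 nM. Both steps away from compound 1 lower the number: a 2.5-fold lower number from compound 1 to compound 2 (0.40 log units; beyond the scatter) and a 2.9-fold lower number from compound 1 to compound 3 (0.46 log units; beyond the scatter). Between the two smaller aromatic ends the difference is slight: a 1.1-fold lower number from compound 2 to compound 3 (0.06 log units; within the scatter).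

Compound 4 `C=C/C=C\[C@H](C)[C@H](OC(N)=O)[C@@H](C)[C@H](O)[C@@H](C)C/C(C)=C\[C@H](C)[C@@H](O)[C@@H](C)/C=C\CCc1ccsc1` differs from compound 1 in one place: thiophen-3-yl in place of 3-fluoro-4-methylphenyl on a saturated chain carbon, two bonds along the chain from a double-bonded chain carbon. The measured steps that bear on this change are those that strip substituents from the aromatic end of the chain, above all the step to compound 3, which exchanges the whole substituted ring for a plain one and lowered the number modestly. The thiophen-3-yl ring, like the phenyl of compound 3, carries no methyl and no fluoro, so a modest drop from compound 1 of similar size is expected: a 2.5-fold lower number from compound 1 to compound 4 (0.40 log units; beyond the scatter). Compound 4 is therefore estimated at 400 nM in this assay, with an expected range from 150 nM to 1100 nM.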

Compound 4, half-maximal inhibitory concentration: 440 nM
For compound 4 the middle estimate is 1.1-fold (0.04 log units) below the measured one, and the stated range covers the measured number.
By their numbers in this assay, from the lowest: compounds 3, 2 and 4 (each within the scatter of the next); then compound 1.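

The result shows that the six-membered carbon ring is not required at this end of the chain in this assay: thiophen-3-yl, with its five-membered aromatic ring holding 1 hetero atom, also gives a 2.3-fold lower number from compound 1 to compound 4 (0.36 log units; beyond the scatter), a modest step beyond the scatter. Compared with the unsubstituted or singly substituted aromatic ends, the exchange is silent, with a 1.3-fold higher number from compound 3 to compound 4 (0.10 log units; within the scatter) and a 1.1-fold higher number from compound 2 to compound 4 (0.04 log units; within the scatter), so in this assay compound 2, compound 3 and compound 4 cannot be told apart. No measurement of any property of these groups is available to account for this result.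

Still open, as far as these compounds go, is whether a thiophen-2-yl, furan-3-yl or pyridin-3-yl ring would fit the same pattern. Also open, from the compounds shown here alone, is how a methyl group on the thiophene ring, an amine on the ring or a longer chain leading to it would shift the number.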